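Swapping 4-aminophenyl for thiophen-2-yl on the shared core

The compounds below may be only part of what the source reports. "The series", "measured", "known", "first", "only" and "open" are said of these compounds alone.

Measured in a functional assay on U-251 cells (Homo sapiens) for antiproliferative activity, read by MTT assay, with a stated time of 48 h; a higher number here means a weaker inhibitor, a lower number a stronger inhibitor:
- compound 1 `COc1cc(-c2cccc3nc(-c4cccc(Cl)c4)oc23)cc(OC)c1OC`: 18500 nM
- compound 2 `COc1cc(-c2cccc3nc(-c4ccc(Cl)cc4)oc23)cc(OC)c1OC`: 1600 nM
- compound 3 `COc1cc(-c2cccc3nc(-c4ccc(N)cc4)oc23)cc(OC)c1OC`: 1040 nM

Compound 3 gives 1040 nM, which puts it level with compound 2, as the comparison shows: a 1.5-fold lower number from compound 2 to compound 3 (0.19 log units; within the scatter). Both stand well clear of compound 1: an 18-fold lower number from compound 1 to compound 3 (1.25 log units; beyond the scatter).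

The next structure, compound 4 `COc1cc(-c2cccc3nc(-c4cccs4)oc23)cc(OC)c1OC`, carries thiophen-2-yl in place of 4-aminophenyl on an aromatic carbon. For the measured compounds named here, no measured step exchanges a six-membered ring for a five-membered one here, so the evidence is indirect. Two steps show that this place can matter a great deal: besides the one just given, 4-chlorophenyl in place of 3-chlorophenyl produced a 12-fold lower number from compound 1 to compound 2 (1.06 log units; beyond the scatter). Amino in place of chloro, by contrast, produced no change beyond the scatter. Compound 3 therefore offers no assurance that a new ring will hold its number. A moderate rise in this assay is expected, staying inside the span the three compounds already cover, though a result level with compound 3 remains possible. The expected change is a 2.9-fold higher number from compound 3 to compound 4 (0.46 log units; beyond the scatter). The estimate for compound 4 is 3000 nM, with an expected range from 800 nM to 12000 nM.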

Compound 4, half-maximal inhibitory concentration: 3000 nM
The estimate for compound 4 equals the measured number at the digits printed, and the stated range covers the measured number.
By their numbers in this assay, from the lowest: compounds 3, 2 and 4 (each within the scatter of the next, the first and the last beyond it); then compound 1.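

In this assay, this place on the shared core also takes a five-membered aromatic ring: putting thiophen-2-yl for 4-aminophenyl gives a 2.9-fold higher number from compound 3 to compound 4 (0.46 log units; beyond the scatter) and so costs something modest, while the swap for 4-chlorophenyl gives a 1.9-fold higher number from compound 2 to compound 4 (0.27 log units; within the scatter) and leaves the two compounds indistinguishable. Compared with the 3-chlorophenyl compound, the same ring gives a 6.2-fold lower number from compound 1 to compound 4 (0.79 log units; beyond the scatter) and so stays well clear of the highest number in the set, which shows that a six-membered ring is not required here for a result close to those of compound 2 and compound 3. Nothing measured in this set explains why these numbers differ.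

The step from compound 3 changes ring size, brings in sulfur and removes the amino group all at once, and the compounds shown cannot separate these three changes. A furan-2-yl ring, with oxygen in place of sulfur, or a thiophene ring carrying an amine would help pull them apart.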